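The compounds below may be only part of what the source reports. "The series", "measured", "known", "first", "only" and "open" are said of these compounds alone.

Measured so far in a functional assay on ECa-109 cells for inhibition, with ECa-109 cell line (Homo sapiens) as the target, read by sulforhodamine B assay; on this read-out higher numbers stand for weaker inhibition and lower numbers for stronger inhibition:
Compound 1, `O=C1C=C(NCc2ccccc2)C(=O)c2c1nc1n2[C@H]2OC[C@@H](O)[C@H]2OC1`, reaches in this assay only a limit, > 8000 nM.
Compound 2, `COc1ccccc1NC1=CC(=O)c2c(nc3n2[C@H]2OC[C@@H](O)[C@H]2OC3)C1=O`, likewise reaches only a limit, > 4000 nM.
Compound 3, `COc1cccc(NC2=CC(=O)c3c(nc4n3[C@H]3OC[C@@H](O)[C@H]3OC4)C2=O)c1`, gives 3340 nM.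

All three share one core and differ only in the group carried on the amine nitrogen. Compound 1 stands at the limit of > 8000 nM in this assay, at which 1 of the 3 values shown sits, so no number is known for it. Compound 2 stands at the limit of > 4000 nM in this assay, at which 1 of the 3 values shown sits. Only compound 3 has a true number.

Compound 4, `O=C1C=C(Nc2cccc(Cl)c2)C(=O)c2c1nc1n2[C@H]2OC[C@@H](O)[C@H]2OC1`, differs from compound 1 by 3-chlorophenyl in place of benzyl on an amine nitrogen. Going by the values given here, the single measured step, an at least 1.1-fold lower number from compound 2 to compound 3 (0.07 log units; that floor lies within the scatter), moves a methoxy group within a phenyl ring and does not touch the exchange of benzyl for 3-chlorophenyl; it also stays within the scatter. Compound 3, which carries a 3-methoxyphenyl on the same nitrogen, is the nearest guide to where a 3-chlorophenyl might land, and its value 3340 nM sets the expected level. With compound 1 at a limit, the size of the step remains uncertain. Compound 4 is therefore expected at 2500 nM, between 900 nM and 8000 nM. That would mean an expected at least 3.2-fold lower number from compound 1 to compound 4 (0.50 log units; beyond the scatter).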

Compound 4, half-maximal inhibitory concentration: 4690 nM
The estimate for compound 4 lay 1.9-fold (0.27 log units) below the measured number; low and high end bracket the measured number.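

Replacing benzyl with 3-chlorophenyl on the amine nitrogen gives a true number where benzyl gave only a limit, so a group at this position can bring a measurable value in this assay. The change amounts to an at least 1.7-fold lower number from compound 1 to compound 4 (0.23 log units; that floor lies within the scatter), and a floor of that size does not by itself show a real gain. The actual size of the step remains unknown because compound 1 gives only a limit: the limit of > 8000 nM in this assay, at which 1 of the 4 values shown sits.

On this nitrogen, compound 3 gives 3340 nM and compound 4 gives 4690 nM, leaving open whether a phenyl ring carrying an amine or a carboxylic acid would shift the value. Also open, on these data alone, is whether a longer chain such as 2-phenylethyl, or 3-chlorobenzyl, would reach a true number.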